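A few compounds are considered here, and "the series" means these few. Any claim that something is new, unique, unknown or untested is made for them only; others in the source may bear on it.

Measured compounds:
- compound 1 `CO[C@@H]1CC=C2NN(c3ccc(Cl)cc3)C(=O)C[C@]2(C)O1` gives 31700 nM in a functional assay on SK-N-SH cells (Homo sapiens) for inhibition, read by sulforhodamine B assay, with a stated time of 48 h; a lower number here means a stronger inhibitor, a higher number a weaker inhibitor
- compound 2 `CO[C@@H]1CC=C2NN(c3ccc(C)cc3)C(=O)C[C@]2(c2ccncc2)O1` gives 8100 nM in this assay
- compound 3 `COc1cc(OC)cc(N2NC3=CC[C@@H](OC)O[C@@]3(C)CC2=O)c1` gives 23700 nM in this assay

Compound 1 carries the highest number of the three. Its nearest neighbour is compound 3, whose number lies within the scatter of it, so no order between compound 1 and compound 3 can be read from these two values. Compound 2 gives a number clearly lower than that of compound 1, beyond the scatter, and so is the stronger inhibitor of that pair. All three numbers sit in a weak range.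

Compound 4 `CO[C@@H]1CC=C2NN(c3cncnc3)C(=O)C[C@]2(C)O1` is the next point in the series. It differs from compound 1 in one place: pyrimidin-5-yl in place of 4-chlorophenyl on an amide-type nitrogen in a ring. For the measured compounds named here, no pair in the measured set isolates a change of this kind on the amide-type nitrogen, so nothing measured here tells how much the number should move.

Given that, the expectation for compound 4 is a step from compound 1 of no more than the usual scatter, with the number left in the same weak range: a 1.3-fold higher number from compound 1 to compound 4 (0.10 log units; within the scatter). In numbers, compound 4 is expected to give 40000 nM in this assay, with a range from 12000 nM to 130000 nM.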

Compound 4, half-maximal inhibitory concentration: 16600 nM
Compound 4: middle estimate off by 2.4-fold (0.38 log units), on the high side, and the stated range covers the measured number.
By their numbers in this assay, from the lowest: compound 2; then compounds 4, 3 and 1 (each within the scatter of the next).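

In this assay, for the compounds shown here, the exchange of 4-chlorophenyl for pyrimidin-5-yl on the amide-type nitrogen in a ring gives a 1.9-fold lower number from compound 1 to compound 4 (0.28 log units; within the scatter), the first step that isolates this position. A ring of carbon only and a ring with 2 hetero atoms therefore cannot be told apart here, and neither the chlorine nor the carbon-only ring is needed to hold the number in the same weak range. The entering group brings 2 hydrogen-bond acceptors where the leaving group has 0, yet this difference produces no step beyond the scatter, and no independent measurement is available to bear on this result.

Going by these compounds alone, with only one step at this position, it remains open whether an amine, a carboxylic acid or a longer alkyl chain on the amide-type nitrogen would move the number beyond the scatter. Also open, going by these compounds, is whether pyrimidin-5-yl would give a similar result on a core carrying a group other than methyl, such as ethyl or cyclopropyl, on the ring atom that bears the methyl group in compound 4.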